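This account rests on a few compounds, and the source may have more. Where it says the series, first, only, none or still open, it means among the compounds named here.

Measured compounds:
- compound 1, `COC(=O)CCCCCOc1cc(-c2ccccc2)cc(-c2ccccc2)n1`: 40 nM
- compound 2, `CC(CCCCOc1cc(-c2ccccc2)cc(-c2ccccc2F)n1)C(=O)O`: 4 nM

Notes on the series. In an assay on cell membranes from spleen (Cavia porcellus) for binding affinity to leukotriene B4 receptor 1 (Homo sapiens) (on this read-out higher numbers stand for weaker inhibition and lower numbers for stronger inhibition), compound 1 gives 40 nM and stands at the highest of the two numbers recorded. For the measured compounds named here, its nearest neighbour is compound 2, whose value in this assay is 4 nM, a gap that lies beyond the usual scatter of this assay; no single-point step between the two has been worked out, so only the two values themselves are noted.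

The next compound to be measured is compound 3, `N#CCCCCCOc1cc(-c2ccccc2)cc(-c2ccccc2)n1`. Relative to compound 1 the change is cyano in place of methoxycarbonyl on a saturated chain carbon, five bonds along the chain from an oxygen on an aromatic ring. The shared core and the chain are kept throughout.

Going by the values given here, no measured pair shows this particular exchange, so no step size is known for it. The working expectation is a step from compound 1 to compound 3 of a 1.5-fold higher number from compound 1 to compound 3 (0.18 log units; within the scatter), that is, a move of no more than the scatter in this assay, perhaps leaning toward a slightly higher number. Compound 3 is accordingly estimated at 60 nM, with a range from 20 nM to 200 nM.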

Compound 3, half-maximal inhibitory concentration: 700 nM
The estimate for compound 3 lay 12-fold (1.07 log units) below the measured number; measured number above the stated range.
By their numbers in this assay, from the lowest: compound 2; then compound 1; then compound 3.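

In this assay cyano in place of methoxycarbonyl on a saturated chain carbon, five bonds along the chain from an oxygen on an aromatic ring, gives an 18-fold higher number from compound 1 to compound 3 (1.24 log units; beyond the scatter) and shows that the number depends strongly on the group at this chain end. For the compounds shown here, this is the first exchange read at this position with the shared core and the chain held fixed, which compound 2, differing from compound 1 in more than one place, could not show. No measurement at hand accounts for the size of this step.

Going by these compounds, it remains open whether the higher number of compound 3 reflects the loss of the methoxycarbonyl group or the presence of the cyano group. A primary amide or an amine at the same chain end, or cyano on a longer chain, would help separate these readings.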